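The source may hold more compounds than are shown below. What is called first, only, known or untested is meant among the compounds shown, and "the series" means these compounds.

Three urea compounds share one core and differ only in a single group on the fused ring. Compound 1 `O=C(Nc1ccc(-n2ncc3c(C(F)(F)F)cccc32)cc1)Nc1ccc(Cl)c(C(F)(F)F)c1` carries a trifluoromethyl there, and in a functional assay on HepG2 cells (Homo sapiens) for cytotoxicity, read by MTT assay, with a stated time of 72 h (on this read-out higher numbers stand for weaker inhibition and lower numbers for stronger inhibition), compound 1 gives 8000 nM. Compound 2 `O=C(Nc1ccc(-n2ncc3c(F)cccc32)cc1)Nc1ccc(Cl)c(C(F)(F)F)c1` carries a fluoro and in this assay compound 2 gives 29500 nM. Compound 3 `Cc1cccc2c1cnn2-c1ccc(NC(=O)Nc2ccc(Cl)c(C(F)(F)F)c2)cc1` carries a methyl and in this assay compound 3 gives 4000 nM. Going by the values given here, of the three numbers, the one for compound 3 is the lowest, yet a 2.0-fold lower number from compound 1 to compound 3 (0.30 log units; within the scatter) is within the scatter, so compound 1 and compound 3 are not separated, while a 7.4-fold lower number from compound 2 to compound 3 (0.87 log units; beyond the scatter) and a 3.7-fold higher number from compound 1 to compound 2 (0.57 log units; beyond the scatter) do stand beyond it.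

Compound 4 `O=C(Nc1ccc(-n2ncc3ccccc32)cc1)Nc1ccc(Cl)c(C(F)(F)F)c1` removes the methyl: hydrogen in place of methyl on an aromatic carbon. Among the compounds with values here, no measured step swaps a methyl for a hydrogen. The nearest guide is that the smallest group tested, fluoro in compound 2, gave the highest number, so a hydrogen is expected to move the number upward by a modest amount, though the step from compound 1 to compound 3 shows how little some swaps at this position matter. The estimated step is a 2.3-fold higher number from compound 3 to compound 4 (0.35 log units; beyond the scatter). Compound 4 is therefore expected to give about 9000 nM, within a range of 3500 nM to 25000 nM.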

Compound 4, half-maximal inhibitory concentration: 8000 nM
The estimate for compound 4 lay 1.1-fold (0.05 log units) above the measured number; measured number inside the range.
By their numbers in this assay, from the lowest: compounds 3, 1 and 4 (each within the scatter of the next); then compound 2.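

In this assay, hydrogen now serves as a plain baseline for this position on the shared core, and two of the swaps leave the number where it was: a 2.0-fold higher number from compound 3 to compound 4 (0.30 log units; within the scatter) and no change at the digits printed from compound 1 to compound 4 (within the scatter). Neither methyl nor trifluoromethyl is therefore separated from having no added group at all on this aromatic carbon, whereas fluoro does stand apart, with a 3.7-fold lower number from compound 2 to compound 4 (0.57 log units; beyond the scatter), so compound 2 remains the weakest of the four and its high number does not come simply from lacking a larger group. Nothing available here explains why fluoro alone behaves differently.

As far as these compounds go, it remains open whether fluoro is a lone exception or whether other groups on the same carbon, such as chloro, methoxy, an amine or a nitrile, would also shift the number beyond the scatter. The compounds shown also leave open whether a methyl or a fluoro on another carbon of this ring would give the same picture.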